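The source may report more compounds than this note shows. Statements on the series, on what has been measured and on what is new or still open speak of the compounds shown alone.

Measured so far in a functional assay on HeLa cells (Homo sapiens) for inhibition, read by MTT assay, with a stated time of 72 h; on this read-out lower numbers stand for stronger inhibition and higher numbers for weaker inhibition:

- Compound 1 `CC(C)C[C@H](NC(=O)CC[C@H](NC(=O)OC(C)(C)C)C(=O)NCc1ccc2ccccc2c1)B(O)O`: > 10000 nM
- Compound 2 `CC(C)C[C@H](NC(=O)CCC[C@H](NC(=O)CNC(=O)OC(C)(C)C)C(=O)NCc1ccc2ccccc2c1)B(O)O`: > 10000 nM
- Compound 3 `CC(C)C[C@H](NC(=O)CCC[C@H](NC(=O)[C@H](C)NC(=O)OC(C)(C)C)C(=O)NCc1ccc2ccccc2c1)B(O)O`: > 10000 nM

Each of these entries is a limit of the assay and not a number. Compound 2 therefore has no exact place on the scale, and its entry remains the limit > 10000 nM. It does not stand apart from the other two compounds, as the whole picture so far is the limit of > 10000 nM in this assay, at which 3 of the 3 values shown sit.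

The change to compound 4 `CC(C)C[C@H](NC(=O)CC[C@H](NC(=O)CNC(=O)OC(C)(C)C)C(=O)NCc1ccc2ccccc2c1)B(O)O` is small: a group of 11 heavy atoms (6 carbon, 1 boron, 1 nitrogen, 3 oxygen; no ring) in place of a group of 12 heavy atoms (7 carbon, 1 boron, 1 nitrogen, 3 oxygen; no ring), on a saturated chain carbon, three bonds along the chain from an amide-type nitrogen and a carbonyl carbon. Neither the leaving group nor the entering group has a ring, and neither carries a net charge.

Within the data shown here, only one measured step exists, and it is a different change: a step that the two limits leave unreadable from compound 2 to compound 3. It places methyl where hydrogen stood, and it gives no size to carry over. Compound 1 also carries the entering group, and it shows the limit > 10000 nM.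

On this evidence, no step beyond the usual scatter is expected in this assay, and no direction can be assigned. A result reported only as a limit is the likeliest outcome.

The estimated step is a step that the limit leaves unreadable from compound 2 to compound 4.

For compound 4 the expected value is 15000 nM, with an estimated range of 4000 nM to 50000 nM.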

Compound 4, half-maximal inhibitory concentration: 350 nM
Beside the measured number, compound 4's estimate is 43-fold (1.63 log units) above it; the whole stated range lies above it.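

In this assay, this saturated chain carbon, three bonds along the chain from an amide-type nitrogen and a carbonyl carbon, proves sensitive: a group of 11 heavy atoms in place of a group of 12 heavy atoms gives an at least 28-fold lower number from compound 2 to compound 4 (1.45 log units; beyond the scatter). The other end of the molecule matters as well, since ((tert-butoxycarbonyl)amino)methyl in place of tert-butoxy on a carbonyl carbon gives an at least 28-fold lower number from compound 1 to compound 4 (1.45 log units; beyond the scatter), so neither change alone brings a measurable number, and only compound 4, which carries both, has one. Compound 4 is therefore the first clear signal in this small set, and the other compounds give no graded scale to set it against: the limit of > 10000 nM in this assay, at which 3 of the 4 values shown sit.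

On these data alone, the step from compound 2 to compound 3 cannot be read, so the effect of the added methyl remains unknown, including whether it would be tolerated with the group of 11 heavy atoms. As far as these compounds go, it is also open whether a free amine in place of the tert-butoxycarbonyl-protected amino group of compound 4, or a still shorter chain at the same carbon, would keep this level of inhibition.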